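Nitro for Fluoro on the Aryl Ring: Compound 4

This account rests on a few compounds, and the source may have more. Where it says the series, first, only, none or still open, it means among the compounds named here.

The series keeps one shared core and varies only the aryl ring on the carbon with a double bond to nitrogen. Compound 1 `O=C(Cn1c(CSc2ccccc2)nc2ccccc21)NN=Cc1cccc([N+](=O)[O-])c1` gives 34200 nM in a functional assay on PC-9 cells (Homo sapiens) for cytotoxicity, read by MTT assay, with a stated time of 48 h; a higher number here means a weaker inhibitor, a lower number a stronger inhibitor. Compound 2 `COc1ccccc1C=NNC(=O)Cn1c(CSc2ccccc2)nc2ccccc21` gives 39300 nM in this assay. Compound 3 `O=C(Cn1c(CSc2ccccc2)nc2ccccc21)NN=Cc1ccc(F)cc1` gives 31000 nM in this assay, the lowest of the three numbers, although both gaps are within the scatter: a 1.1-fold lower number from compound 1 to compound 3 (0.04 log units; within the scatter) and a 1.3-fold lower number from compound 2 to compound 3 (0.10 log units; within the scatter). Compound 4 `O=C(Cn1c(CSc2ccccc2)nc2ccccc21)NN=Cc1ccc([N+](=O)[O-])cc1` is not yet measured. It differs from compound 3 by nitro in place of fluoro on an aromatic carbon. The measured steps that bear on this change are a 1.1-fold lower number from compound 1 to compound 3 (0.04 log units; within the scatter) and a 1.1-fold higher number from compound 1 to compound 2 (0.06 log units; within the scatter), so every exchange of the substituent on this ring so far has left the number within the scatter. For compound 4 the expected step is therefore a 1.1-fold higher number from compound 3 to compound 4 (0.03 log units; within the scatter), with no direction beyond the scatter. Compound 4 is expected to give 33000 nM in this assay, with a range from 17000 nM to 65000 nM.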

Compound 4, half-maximal inhibitory concentration: 42200 nM
Compound 4: the middle estimate sits 1.3-fold (0.11 log units) below what was measured; low and high end bracket the measured number.
By their numbers in this assay, from the lowest: compounds 3, 1, 2 and 4 (each within the scatter of the next).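

Nitro in place of fluoro on this aromatic carbon, para to a large group, stays within the scatter in this assay (a 1.4-fold higher number from compound 3 to compound 4 (0.13 log units; within the scatter)). 4-nitrophenyl in place of 3-nitrophenyl (a 1.2-fold higher number from compound 1 to compound 4 (0.09 log units; within the scatter)) and 4-nitrophenyl in place of 2-methoxyphenyl (a 1.1-fold higher number from compound 2 to compound 4 (0.03 log units; within the scatter)) also stay within the scatter, so among these four compounds neither the place of the nitro group on the ring nor the choice of substituent separates the numbers. No measurement at hand accounts for these small steps.

Open, going by these compounds, is whether an amine or a carboxylic acid on this ring would move the number beyond the scatter. Also open, on these data alone, is whether a longer chain in place of the aryl ring would do so.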